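Swapping the acyl group on a trimethoxyaniline amide

This account rests on a few compounds, and the source may have more. Where it says the series, first, only, none or still open, it means among the compounds named here.

The series is examined in a functional assay on HCT-116 cells (Homo sapiens) for inhibition, read by MTT assay, with a stated time of 48 h; on this read-out lower numbers stand for stronger inhibition and higher numbers for weaker inhibition. Compound 1 `COCC(=O)N(Cc1ccc(OC)c(O)c1)c1cc(OC)c(OC)c(OC)c1` gives 230 nM and is the lowest of the two numbers recorded. Compound 3 `COc1ccc(CNc2cc(OC)c(OC)c(OC)c2)cc1Br`, which has no carbonyl group on the nitrogen, gives 48100 nM in this assay, a far higher number that lies well beyond the scatter. Compound 2 `COc1cc(NCc2ccc(Cl)cc2)cc(OC)c1OC` reaches only the limit of the assay in this assay, at > 80000 nM, so no number is known for it; this is the situation described by the limit of > 80000 nM in this assay, at which 1 of the 3 values shown sits. Among the compounds with values here, no pair of measured compounds differs in a single place, so no measured step is available.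

The step of interest leads from compound 1 to compound 4 `C=C(C)C(=O)N(Cc1ccc(OC)c(O)c1)c1cc(OC)c(OC)c(OC)c1`, which is not yet measured. The change is 1-methylethenyl in place of methoxymethyl on a carbonyl carbon. Both groups are of the same size and neither carries a ring; the group that leaves brings one hydrogen-bond acceptor, the group that enters brings a double bond outside aromatic rings and no acceptor. Within the data shown here, with no measured step to lean on, compound 4 is expected to stay close to compound 1 in this assay, with a shift from compound 1 to compound 4 of a 1.3-fold higher number from compound 1 to compound 4 (0.12 log units; within the scatter), not clearly beyond the scatter. Compound 4 is therefore estimated at 300 nM, within a range from 80 nM to 1200 nM.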

Compound 4, half-maximal inhibitory concentration: 200 nM
For compound 4 the middle estimate is 1.5-fold (0.18 log units) above the measured one; low and high end bracket the measured number.
By their numbers in this assay, from the lowest: compounds 4 and 1 (each within the scatter of the next); then compound 3. At a limit, above all of these: compound 2.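

In this assay, within the data shown here, the exchange of methoxymethyl for 1-methylethenyl on a carbonyl carbon whose other neighbour is the amide-type nitrogen gives the first step that can be read at a single place: a 1.2-fold lower number from compound 1 to compound 4 (0.06 log units; within the scatter) lies within the scatter. At this position, then, a group with no hydrogen-bond acceptor and a double bond outside aromatic rings cannot be told apart from a group of the same heavy-atom count that brings one acceptor, so the acceptor of methoxymethyl is not required for a number of this size. No measured property among the data shown bears on this result.

Going by these compounds, both groups compared have the same heavy-atom count and neither carries a ring, so how a longer chain, a phenyl ring, an aminomethyl group or a carboxylic acid on this carbonyl carbon would read in this assay remains open. Also open, on these data alone, is how isopropyl, which has the carbon count of 1-methylethenyl but no double bond, would read in the same place.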